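The compounds below may be only part of what the source reports. "The series", "measured", "known", "first", "only" and "open" are said of these compounds alone.

In an ADME assay on microsomes from liver (Rattus norvegicus) for metabolic stability, with a stated time of 10 min, tested at 0.5 uM (on this read-out higher numbers stand for a more stable compound and lower numbers for a less stable compound), compound 3 (`Cc1noc(-c2ccc(F)cc2)c1[C@@H]1C[C@@](C)(c2ccc(F)cc2F)N=C(N)S1`) gives 88% and holds the highest of the three numbers, with compound 1 (`CCc1noc(C)c1[C@@H]1C[C@@](C)(c2ccc(F)cc2F)N=C(N)S1`) at 59% and compound 2 (`Cc1noc(-c2ccccc2)c1[C@@H]1C[C@@](C)(c2ccc(F)cc2F)N=C(N)S1`) at 20% lower. Compound 4 (`Cc1nocc1[C@@H]1C[C@@](C)(c2ccc(F)cc2F)N=C(N)S1`) has hydrogen in place of 4-fluorophenyl (hydrogen in place of 4-fluorophenyl on an aromatic carbon). Within the data shown here, the one measured step on that group (a number 68 percentage points higher from compound 2 to compound 3 (beyond the scatter)) is large, but it is fluoro in place of hydrogen and does not remove the group. Compound 1 also lacks 4-fluorophenyl, stands at 59% and is the nearest guide, though it differs elsewhere too. A moderate fall is therefore expected, estimated as a number 20 percentage points lower from compound 3 to compound 4 (beyond the scatter) (a lower number, with wide uncertainty). Compound 4 is expected at 68% (estimated range 45% to 88%).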

Compound 4, percent of the compound remaining: 77%
Compound 4: the middle estimate sits 9 percentage points below what was measured; low and high end bracket the measured number.
By their numbers in this assay, from the lowest: compound 2; then compound 1; then compound 4; then compound 3.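

In this assay, hydrogen in place of 4-fluorophenyl gives a number 11 percentage points lower from compound 3 to compound 4 (beyond the scatter), so a high number at this aromatic carbon does not depend on an aromatic substituent. Hydrogen in place of phenyl gives a number 57 percentage points higher from compound 2 to compound 4 (beyond the scatter), which singles out the unfluorinated phenyl of compound 2 as the poor case here, while 3-methyl-1,2-oxazol-4-yl in place of 3-ethyl-5-methyl-1,2-oxazol-4-yl gives a number 18 percentage points higher from compound 1 to compound 4 (beyond the scatter). Nothing available explains these differences.

The compounds shown leave open how a methyl, a methoxy or an amine on this carbon would compare with hydrogen. They also leave open whether chloro on the phenyl would match fluoro.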